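Swapping one side group on compound 3

The source may hold more compounds than are shown below. What is called first, only, known or untested is meant among the compounds shown, and "the series" means these compounds.

Compound 1 (`CC(C)(NC(=O)COC(=O)c1ccc([N+](=O)[O-])o1)c1ccccc1`) gives > 100000 nM as a limit
Compound 2 (`O=C(COC(=O)c1ccc([N+](=O)[O-])o1)NC1CCc2ccccc21`) gives > 100000 nM as a limit
Compound 3 (`CC(C)(C)N(CCC(=O)c1ccccc1)C(=O)COC(=O)c1ccc([N+](=O)[O-])o1`) gives "not active" (no number reported) with no number

In an ADME assay on HEK-293T cells (Homo sapiens) for cytotoxicity, read by MTT assay, with a stated time of 3 days (on this read-out higher numbers stand for lower toxicity in this test and lower numbers for higher toxicity in this test), compound 1 gives > 100000 nM as a limit of the assay and not a number. Compound 2 likewise gives > 100000 nM as a limit and not a number. Compound 3 has no number at all and is reported as "not active" (no number reported) in this assay only. Taken together, this is the limit of > 100000 nM in this assay, at which 2 of the 3 values shown sit, and leaves compound 3 with no figure to start from.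

Compound 4 (`CC(=O)Oc1ccccc1CN(C(=O)COC(=O)c1ccc([N+](=O)[O-])o1)C(C)(C)C`) has not been measured. The change 2-acetoxyphenyl in place of benzoylmethyl on a saturated chain carbon bound to an amide-type nitrogen puts 2-acetoxyphenyl in place of benzoylmethyl on a saturated chain carbon bound to an amide-type nitrogen. For the measured compounds named here, no measured step between similar compounds exists to guide the size of this one. With compound 3 reported as "not active" (no number reported) here, the expected change in this assay is none beyond the scatter, in either direction. For compound 4 the estimated value is 90000 nM within an expected range from 30000 nM to 100000 nM and may well come back only as a limit.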

Compound 4, half-maximal cytotoxic concentration: > 100000 nM
Compound 4: only a limit was reported; the forecaster's own chance of this, stated with the estimate: 70%; middle value at least 1.1-fold (0.04 log units) away from the limit.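

Compound 3 has no number in this assay. Compound 4 gives > 100000 nM, which is a limit and not a number, so no step can be read between compound 3 and compound 4. Going by these compounds, whether 2-acetoxyphenyl in place of benzoylmethyl changes cytotoxicity at all remains open.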